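Fluorophenyl Replacing Cyclopropyl on the Ring Nitrogen

A few compounds are considered here, and "the series" means these few. Any claim that something is new, unique, unknown or untested is made for them only; others in the source may bear on it.

Three compounds sharing the same core were measured in a functional assay on HeLa cells (Homo sapiens) for antiproliferative activity, read by MTT assay, with a stated time of 72 h; a higher number here means a weaker inhibitor, a lower number a stronger inhibitor. Compound 1 `O=C1COc2ccc(-c3cccc(NS(=O)(=O)c4ccc(F)cc4)c3)cc2N1C1CC1` returns only a limit, > 40000 nM, so where it truly stands on the scale is not known. Compound 2 `COc1cccc(N2C(=O)COc3ccc(-c4ccc(O)cc4)cc32)c1` also returns only a limit, > 40000 nM. Going by the values given here, compound 3 `COc1ncc(-c2ccc3c(c2)NC(=O)CO3)cc1NS(=O)(=O)c1ccc(F)cc1`, which carries hydrogen rather than a substituent on the amide-type nitrogen in a ring, is the one compound with a number, 7110 nM. Among the compounds with values here, the picture is shaped by the limit of > 40000 nM in this assay, at which 2 of the 3 values shown sit, and no pair of measured compounds differs in a single place, so no measured step is available.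

Compound 4 `O=C1COc2ccc(-c3cccc(NS(=O)(=O)c4ccc(F)cc4)c3)cc2N1c1ccc(F)cc1` has not yet been measured. It differs from compound 1 in one place: 4-fluorophenyl in place of cyclopropyl on an amide-type nitrogen in a ring. The nearest guide is compound 2, which also carries an aromatic ring on that nitrogen and stands at > 40000 nM. With an aromatic ring replacing cyclopropyl on the same nitrogen, the step of a number no higher from compound 1 to compound 4 (the limit leaves the size open) is expected to be flat, with no change beyond the scatter. Compound 4 is therefore estimated to give 40000 nM, within a range from 12000 nM to 120000 nM, and most probably the assay will again report only a limit.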

Compound 4, half-maximal inhibitory concentration: > 40000 nM
Compound 4 gave a limit, no number; the forecaster's own chance of this, stated with the estimate: 70%; the middle value lies on the limit itself.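

Going by these compounds alone, compound 1 and compound 4 each return only a limit rather than a number, so the change from cyclopropyl to 4-fluorophenyl gives no step that can be read: the limit of > 40000 nM in this assay, at which 3 of the 4 values shown sit. Still open, on these data alone, is where either compound truly stands in this assay, and whether the group on the amide-type nitrogen in a ring alters activity at all.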